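The source may report more compounds than this note shows. Statements on the series, on what has been measured and on what is new or still open speak of the compounds shown alone.

Working notes on the series, all read in a functional assay on DU-145 cells (Homo sapiens) for inhibition, read by trypan blue exclusion, with a stated time of 96 h; on this read-out lower numbers stand for stronger inhibition of growth and higher numbers for weaker inhibition of growth. Compound 1 (`O=C(/C(=C\c1ccccc1OCc1ccccc1)SCc1ccc(F)cc1)c1ccc(Cl)cc1`) gives 1000 nM. Going by the values given here, compound 2 (`O=C(/C(=C\c1ccc(Br)cc1)Sc1ccccc1Br)c1ccc(Br)cc1`) gives 1000 nM, level with compound 1, and these two share the lowest number of the three measured so far. Compound 3 (`Cc1ccc(CS(=O)(=O)/C(=C/c2ccc(N(C)C)cc2)C(=O)c2ccc(Cl)cc2)cc1`) gives 50000 nM, a number beyond the scatter from that of compound 1.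

Compound 4 (`O=C(/C(=C\c1ccccc1OCc1ccccc1)SCc1ccc(Cl)c(Cl)c1)c1ccc(Cl)cc1`) has not been measured and keeps the core of compound 1. The change is 3,4-dichlorophenyl in place of 4-fluorophenyl on a saturated chain carbon bound to a sulfur. Cut one bond further out, it reads 4-fluorobenzyl to 3,4-dichlorobenzyl.

Among the compounds with values here, the measured compounds offer no pair that differs in one place, so this change has no direct precedent. Going by these compounds, no step beyond the scatter is expected, and the direction stays open. The estimated step is a 1.3-fold lower number from compound 1 to compound 4 (0.10 log units; within the scatter). For compound 4 the expected value is 800 nM, with an estimated range of 250 nM to 3000 nM.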

Compound 4, concentration for 50% growth inhibition: 10000 nM
For compound 4 the middle estimate is 13-fold (1.10 log units) below the measured one, outside the stated range (above it).
By their numbers in this assay, from the lowest: compounds 1 and 2 (each within the scatter of the next); then compound 4; then compound 3.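

In this assay, going by these compounds alone, the change of 3,4-dichlorophenyl in place of 4-fluorophenyl on a saturated chain carbon bound to a sulfur gives a 10-fold higher number from compound 1 to compound 4 (1.00 log units; beyond the scatter) and is the first single change that can be read. The earlier compounds shown here, with no pair differing in one place, could not show that this position responds to the ring it carries; here, weaker inhibition of growth goes with the 3,4-dichlorobenzyl group. Nothing measured on the series accounts for this step.

Still open, going by these compounds, is how 4-chlorobenzyl or plain benzyl would read in this place, which would separate the effect of the second chlorine from that of exchanging fluorine for chlorine. Also open, on these data alone, is whether a 2-phenylethyl group in place of the benzyl group would keep the number of compound 1 or move it.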